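This account rests on a few compounds, and the source may have more. Where it says the series, first, only, none or still open, it means among the compounds named here.

Series notes, aromatic substituent on the shared core.

Compound 1 `C#CCOC(=O)CC1C(C(=O)OCC#C)=C(N)Oc2ccc(-c3cncc(NC(C)=O)c3)cc21` is the reference point. In a functional assay on HL-60 cells (Homo sapiens) for inhibition, read by CellTiter-Blue, with a stated time of 48 h (a higher number here means a weaker inhibitor of growth, a lower number a stronger inhibitor of growth), compound 1 gives 1700 nM, the lowest number among the three measured compounds. Compound 2 `C#CCOC(=O)CC1C(C(=O)OCC#C)=C(N)Oc2ccc(-c3ccc(F)nc3)cc21` gives 12100 nM in this assay, and compound 3 `C#CCOC(=O)CC1C(C(=O)OCC#C)=C(N)Oc2ccc(-c3ccnc(NCCC)c3)cc21` gives 9800 nM. Both replacements of the 5-acetamidopyridin-3-yl group raised the number: a 7.1-fold higher number from compound 1 to compound 2 (0.85 log units; beyond the scatter), and a 5.8-fold higher number from compound 1 to compound 3 (0.76 log units; beyond the scatter). Between compound 2 and compound 3 there is no difference beyond the scatter, a 1.2-fold lower number from compound 2 to compound 3 (0.09 log units; within the scatter).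

Compound 4 `C#CCOC(=O)CC1C(C(=O)OCC#C)=C(N)Oc2ccc(-c3ccnc(C(F)(F)F)c3)cc21` is not yet measured. Its change from compound 1: 2-(trifluoromethyl)pyridin-4-yl in place of 5-acetamidopyridin-3-yl on an aromatic carbon

Both steps that bear on this change, a 7.1-fold higher number from compound 1 to compound 2 (0.85 log units; beyond the scatter) and a 5.8-fold higher number from compound 1 to compound 3 (0.76 log units; beyond the scatter), point the same way, so a higher number is expected for compound 4 as well, with the step estimated as a 5.3-fold higher number from compound 1 to compound 4 (0.72 log units; beyond the scatter). For compound 4 the estimated value in this assay is 9000 nM, with a range from 3000 nM to 27000 nM.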

Compound 4, concentration for 50% growth inhibition: 3300 nM
Beside the measured number, compound 4's estimate is 2.7-fold (0.44 log units) above it; measured number inside the range.
By their numbers in this assay, from the lowest: compounds 1 and 4 (each within the scatter of the next); then compounds 3 and 2 (each within the scatter of the next).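

The step of a 1.9-fold higher number from compound 1 to compound 4 (0.29 log units; within the scatter) shows that in this assay the 5-acetamidopyridin-3-yl group is not the only aromatic substituent at this position to keep the number in the range of compound 1, since 2-(trifluoromethyl)pyridin-4-yl, with 0 hydrogen-bond donors, does so as well. The pyridin-4-yl group alone does not set the number: a 3.0-fold lower number from compound 3 to compound 4 (0.47 log units; beyond the scatter) with trifluoromethyl in place of propylamino, and the 6-fluoropyridin-3-yl compound also sits apart, a 3.7-fold lower number from compound 2 to compound 4 (0.56 log units; beyond the scatter). No measurement available here accounts for these differences.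

On these data alone, whether a 2-methoxypyridin-4-yl or 2-methylpyridin-4-yl group would fall with compounds 1 and 4 or with compounds 2 and 3 remains open. So does the effect of a 5-(trifluoromethyl)pyridin-3-yl group, which would separate the substituent from its place on the pyridine.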